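Changing the Aromatic Group on a Shared Core

The source may report more compounds than this note shows. Statements on the series, on what has been measured and on what is new or still open speak of the compounds shown alone.

In a functional assay on MDA-MB-231 cells (Homo sapiens) for antiproliferative activity, read by MTT assay, with a stated time of 72 h (a lower number here means a stronger inhibitor, a higher number a weaker inhibitor), compound 1 (`COc1ccc(-c2cccc(NC(=O)CCc3cccc4c3B(O)OC4)c2)cc1`) gives 88 nM and compound 2 (`CSc1cccc(-c2cccc(NC(=O)CCc3cccc4c3B(O)OC4)c2)c1`) gives 150 nM in the same test. Going by the values given here, the one measured step is a 1.7-fold higher number from compound 1 to compound 2 (0.23 log units; within the scatter) and it comes with 3-(methylsulfanyl)phenyl in place of 4-methoxyphenyl, so compound 2 stands level with compound 1 as far as these two numbers can tell.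

Compound 3 (`O=C(CCc1cccc2c1B(O)OC2)Nc1cccc(-c2ccc(C(F)(F)F)cc2)c1`) has not yet been measured. It differs from compound 2 at that same aromatic carbon, with 4-(trifluoromethyl)phenyl in place of 3-(methylsulfanyl)phenyl (4-(trifluoromethyl)phenyl in place of 3-(methylsulfanyl)phenyl on an aromatic carbon). Among the compounds with values here, the group entering here appears in neither measured compound, so the data offer no direct precedent for it. Within the data shown here, the only guide is the earlier exchange at this place, a 1.7-fold higher number from compound 1 to compound 2 (0.23 log units; within the scatter) and that step stayed small. A similarly small step is therefore expected in this assay with no clear direction. The estimated change is a 1.3-fold lower number from compound 2 to compound 3 (0.10 log units; within the scatter) and it is not expected to rise beyond the scatter. The estimated value for compound 3 is 120 nM with an expected range of 50 nM to 300 nM until a measurement settles it.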

Compound 3, half-maximal inhibitory concentration: 510 nM
The estimate for compound 3 lay 4.3-fold (0.63 log units) below the measured number, outside the stated range (above it).
By their numbers in this assay, from the lowest: compounds 1 and 2 (each within the scatter of the next); then compound 3.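

In this assay this aromatic carbon proves not to be indifferent to the group it carries. Placing 4-(trifluoromethyl)phenyl there instead of 3-(methylsulfanyl)phenyl gives a 3.4-fold higher number from compound 2 to compound 3 (0.53 log units; beyond the scatter) and is the first exchange at this place to pass beyond the scatter. The comparison that changes the least, trifluoromethyl in place of methoxy on an aromatic carbon, gives a 5.8-fold higher number from compound 1 to compound 3 (0.76 log units; beyond the scatter) and shows that swapping this one substituent on the phenyl ring is enough to shift the number, whereas the earlier exchange between compound 1 and compound 2 stayed within the scatter. No accompanying measurement bears on this result, so the reason for the higher number remains unknown.

With only three aromatic groups in hand, the compounds shown cannot tell whether the weaker result belongs to trifluoromethyl specifically or to its place on the phenyl ring, a question that 3-(trifluoromethyl)phenyl could help to answer. From the compounds shown here alone, how this carbon would respond to a different kind of substituent on the phenyl ring, such as an amine or a carboxylic acid, also remains open.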